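A Benzyl Selenide Variant of a Bis-Amide Growth Inhibitor

A few compounds are considered here, and "the series" means these few. Any claim that something is new, unique, unknown or untested is made for them only; others in the source may bear on it.

Going by the values given here, compound 1 `C[Se]/C(=N\C(=O)c1cc2ccccc2s1)NC(=O)c1cc2ccccc2s1` is the only compound here with a measured number. In a functional assay on MCF7 cells (Homo sapiens) for cytotoxicity, read by MTT assay, with a stated time of 72 h (a higher number here means a weaker inhibitor of growth, a lower number a stronger inhibitor of growth), compound 1 gives 32700 nM. Compound 2 `CS/C(=N\C(=O)c1cnc2ccccc2c1)NC(=O)c1cnc2ccccc2c1` gives only a limit of the assay, > 100000 nM, with no number behind it. Compound 3 `O=C(/N=C(/NC(=O)c1cc2ccccc2s1)[Se]Cc1ccccc1)c1cc2ccccc2s1` differs from compound 1 in one place: phenyl in place of hydrogen on a saturated chain carbon bound to a selenium atom. Among the compounds with values here, no step between measured compounds is available to guide expectations, so only a modest change in this assay is expected, if any, toward stronger inhibition of growth. For compound 3 the estimate is 20000 nM, within the range 6000 nM to 60000 nM, a step of a 1.6-fold lower number from compound 1 to compound 3 (0.21 log units; within the scatter) that is expected to stay close to the scatter.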

Compound 3, concentration for total growth inhibition: 62900 nM
Compound 3: the middle estimate sits 3.1-fold (0.50 log units) below what was measured, and the stated range ends below it.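

Methyl to benzyl, on a saturated chain carbon bound to a selenium atom, gives a 1.9-fold higher number from compound 1 to compound 3 (0.28 log units; within the scatter) in this assay. This position therefore takes a whole phenyl ring with no change that can be told from the scatter, and compound 3 still returns a measured number. Compound 2 gives only a limit of the assay, not a number: the limit of > 100000 nM in this assay, at which 1 of the 3 values shown sits.

From the compounds shown here alone, whether an amine or a carboxylic acid on this carbon would move the number beyond the scatter stays open. No pair shown differs only at the selenium atom, so its part stays open too.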